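This account rests on a few compounds, and the source may have more. Where it says the series, first, only, none or still open, it means among the compounds named here.

Measured so far:
Compound 1, `COC(=O)C1=C(C)N(C)C(=O)NC1c1ccco1`: 9%
Compound 2, `CCCOC(=O)C1=C(C)N(C)C(=O)NC1c1ccco1`: 8%
Compound 3, `COC(=O)C1=C(C)N(C)C(=O)NC1c1ccoc1`: 7%

In an assay on membranes from HeLa cells for displacement of a labelled ligand from adenosine receptor A3 (Homo sapiens), read by scintillation counting, with a stated time of 180 min, tested at 1 uM (a higher number here means more inhibition at the concentration tested (going by the name of the read-out), a lower number less inhibition), compound 1 gives 9%, compound 2 gives 8% and compound 3 gives 7%. Compound 2 arises from compound 1 by ethyl in place of hydrogen on a saturated chain carbon bound to an oxygen next to a carbonyl group, and that step reads a number 1 percentage points lower from compound 1 to compound 2 (within the scatter). Compound 3 arises from compound 1 by furan-3-yl in place of furan-2-yl on a saturated ring carbon, with a number 2 percentage points lower from compound 1 to compound 3 (within the scatter). Compound 4, `CCCOC(=O)C1=C(C)N(C)C(=O)NC1c1ccoc1`, has not yet been measured; it arises from compound 3 by ethyl in place of hydrogen on a saturated chain carbon bound to an oxygen next to a carbonyl group, the same change as that from compound 1 to compound 2, at the same place. Since the earlier step was a number 1 percentage points lower from compound 1 to compound 2 (within the scatter), the coming step is expected to be similar, no change at the digits printed from compound 3 to compound 4 (within the scatter). On that basis compound 4 is expected to give about 7% in this assay, within a range from 0% to 18%.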

Compound 4, a percentage reported as inhibition, at one concentration (the size of the read-out at that concentration, not a potency): 16%
For compound 4 the middle estimate is 9 percentage points below the measured one; low and high end bracket the measured number.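

In this assay, the ethyl change gives a number 9 percentage points higher from compound 3 to compound 4 (within the scatter) and the furan-3-yl change gives a number 8 percentage points higher from compound 2 to compound 4 (within the scatter), so neither change can be said to read differently on the second core, and this does not show that either one moves the inhibition at all. For the ethyl change, the two cores compare as follows: the same change on two cores in this assay, a number 1 percentage points lower (within the scatter) from compound 1 to compound 2 and a number 9 percentage points higher (within the scatter) from compound 3 to compound 4, 10 percentage points apart, within the scatter of two such steps. For the furan-3-yl change, the comparison is similar: the same change on two cores in this assay, a number 2 percentage points lower (within the scatter) from compound 1 to compound 3 and a number 8 percentage points higher (within the scatter) from compound 2 to compound 4, 10 percentage points apart, within the scatter of two such steps.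

The compounds shown leave open how a longer chain than propoxy, or an amine or a phenyl ring in place of the furan, would read in this assay. Each value is also a read-out at one concentration, so no potency follows from any of them.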